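The compounds below may be only part of what the source reports. "The series", "measured", "known", "first", "only" and "open" are said of these compounds alone.

Measured so far in a functional assay on TK-10 cells (Homo sapiens) for inhibition, read by sulforhodamine B assay, with a stated time of 48 h; a higher number here means a weaker inhibitor of growth, a lower number a stronger inhibitor of growth:
- compound 1, `Nc1cc(N)c2nc(-c3ccccc3)c(Oc3ccc(Cl)c(Cl)c3)nc2c1`, gives 24500 nM
- compound 2, `CCOC(=O)[C@H](CCC(=O)O)NC(=O)c1ccc(Sc2nc3cc(N)cc(N)c3nc2-c2ccccc2)cc1`, gives 53700 nM
- compound 3, `CCOC(=O)[C@H](CCC(=O)O)NC(=O)c1ccc(Oc2nc3cc(N)cc(N)c3nc2-c2ccccc2)cc1`, gives 6310 nM

Among these three numbers compound 1 stands second highest. Its nearest neighbour is compound 2, whose number is higher than that of compound 1 by more than the usual scatter; the furthest is compound 3, whose number is lower than that of compound 1, again beyond the scatter. Compound 2 and compound 3 share the same side chain and differ only in the atom that joins the substituted phenyl to the core, sulfur in compound 2 and oxygen in compound 3, and the oxygen compound gives the lower number.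

The unmeasured compound 4, `COc1ccc(Sc2nc3cc(N)cc(N)c3nc2-c2ccccc2)cc1`, differs from compound 1 by (4-methoxyphenyl)sulfanyl in place of 3,4-dichlorophenoxy on an aromatic carbon. This change puts a sulfur in place of the oxygen of compound 1, the same kind of exchange that separates compound 3 from compound 2. Among the measured compounds shown here, no measured step matches this exact change, so the expectation rests on that pair alone. The step of a 1.8-fold higher number from compound 1 to compound 4 (0.26 log units; within the scatter) is expected to go upward, toward a weaker inhibitor of growth, by clearly more than the scatter. Compound 4 is therefore estimated at 45000 nM, with a range from 15000 nM to 130000 nM.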

Compound 4, concentration for 50% growth inhibition: 12900 nM
Estimate against measurement, compound 4: 3.5-fold (0.54 log units) above, outside the stated range (below it).
By their numbers in this assay, from the lowest: compound 3; then compounds 4 and 1 (each within the scatter of the next); then compound 2.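

In this assay the exchange of 3,4-dichlorophenoxy for (4-methoxyphenyl)sulfanyl on the aromatic carbon next to the ring nitrogen and ortho to a phenyl group gives a 1.9-fold lower number from compound 1 to compound 4 (0.28 log units; within the scatter) and so leaves the number in the same range. The earlier pair with a shared side chain had tied a sulfur link to the higher number, with compound 2 at 53700 nM and compound 3 at 6310 nM, but on this pair a sulfur link comes with no change beyond the scatter, so the sulfur-for-oxygen difference seen there does not carry over to a change of the whole group at this position. Nothing available accounts for this result.

This step changes the linking atom and the ring substituents together, so the part played by each cannot be separated from these compounds alone. As far as these compounds go, whether 4-methoxyphenoxy or (3,4-dichlorophenyl)sulfanyl at this position would stay in the same range, and how an amine or a carboxylic acid on the phenyl ring would read, remains open.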